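From Isopropyl to Cyclopentyl on a Ring Amine

The source may hold more compounds than are shown below. What is called first, only, known or untested is meant among the compounds shown, and "the series" means these compounds.

Compound 3 `CC(C)N1CCCN(CCn2ccc3ccc(Br)cc32)CC1` gives 14 nM in an assay on HEK293 cells for binding affinity to 5-hydroxytryptamine receptor 7 (Homo sapiens), read by radioligand binding (on this read-out lower numbers stand for stronger inhibition and higher numbers for weaker inhibition), the lowest of the three numbers measured. Compound 1 `CN1CCCN(CCn2ccc3ccc(C(F)(F)F)cc32)CC1` gives 23 nM in this assay, a gap that lies within the scatter, while compound 2 `C=Cc1ccc2ccn(CCN3CCCN(C)CC3)c2c1` gives 109 nM in this assay, a gap beyond it. For the measured compounds named here, the only single-point step measured, a 4.7-fold higher number from compound 1 to compound 2 (0.68 log units; beyond the scatter), concerns a substituent on an aromatic carbon and does not touch the ring amine. Compound 4 `Brc1ccc2ccn(CCN3CCCN(C4CCCC4)CC3)c2c1` differs from compound 3 by cyclopentyl in place of isopropyl on an amine nitrogen in a ring. Going by the values given here, no measured pair alters the group on that nitrogen alone; compound 1 and compound 3 differ there, but also on the aromatic ring, so their two values show only that the pair sits close together. With nothing measured bearing on this change, no step beyond the scatter is expected in this assay, no change at the digits printed from compound 3 to compound 4 (within the scatter). Compound 4 is therefore estimated at 14 nM in this assay, within 5 nM to 40 nM.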

Compound 4, inhibition constant: 10 nM
Compound 4: the middle estimate sits 1.4-fold (0.15 log units) above what was measured; low and high end bracket the measured number.
By their numbers in this assay, from the lowest: compounds 4, 3 and 1 (each within the scatter of the next, the first and the last beyond it); then compound 2.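

The step of a 1.4-fold lower number from compound 3 to compound 4 (0.15 log units; within the scatter) is the first change shown that alters only the group on this amine nitrogen in a ring, and in this assay it stays within the scatter. At this position, then, isopropyl with 3 heavy atoms and no ring gives way to cyclopentyl with 5 heavy atoms and a five-membered non-aromatic ring of carbon only, with no shift that this read-out can separate from repeat measurement. Nothing among the data shown offers an account of this result.

Still open, as far as these compounds go, is how far this tolerance of change extends, whether to a larger ring such as cyclohexyl, to a chain ending in a hydroxyl, or to a bare hydrogen on that nitrogen. Also open, from the compounds shown here alone, is how methyl compares with isopropyl or cyclopentyl on this nitrogen when the bromine on the shared core is held fixed.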